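The source may report more compounds than this note shows. Statements on the series, on what has been measured and on what is new or still open speak of the compounds shown alone.

- Compound 1 `CC(C)c1ccc(S(C)(=O)=O)cc1C#Cc1cc(C#N)ccc1OCC(=O)O`: 145 mL/min/kg
- Compound 2 `CCCS(=O)(=O)c1ccc(F)c(C#Cc2cc(Cl)ccc2OCC(=O)O)c1`: 6.67 mL/min/kg
- Compound 3 `CC(C)c1ccc(S(C)(=O)=O)cc1C#Cc1cc(Cl)ccc1OCC(=O)O`: 8.33 mL/min/kg

In an in vivo ADME assay on the whole organism (strain BALB/c) for pharmacokinetics, with Mus musculus as the target, read by LC-MS, at a dose of 5 mg/kg by the oral route (a lower number here means slower removal, a higher number faster removal of the compound), compound 3 gives 8.33 mL/min/kg. That number lies within the scatter of compound 2, and compound 1 is far higher. Compound 4 `Cc1ccc(S(C)(=O)=O)cc1C#Cc1cc(Cl)ccc1OCC(=O)O` has methyl in place of isopropyl on an aromatic carbon, para to a methylsulfonyl group (methyl in place of isopropyl on an aromatic carbon).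

For the measured compounds named here, the only measured step is large, a 17-fold lower number from compound 1 to compound 3 (1.24 log units; beyond the scatter), but it is chloro in place of cyano on an aromatic carbon and leaves the isopropyl untouched. Going by the values given here, no measured step shows what replacing isopropyl does, so no step beyond the scatter is expected. The expected change is a 1.1-fold higher number from compound 3 to compound 4 (0.03 log units; within the scatter). For compound 4, the estimated clearance is 9 mL/min/kg, with an expected range of 4 mL/min/kg to 22 mL/min/kg.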

Compound 4, clearance: 23.3 mL/min/kg
For compound 4 the middle estimate is 2.6-fold (0.41 log units) below the measured one; the whole stated range lies below it.
By their numbers in this assay, from the lowest: compounds 2 and 3 (each within the scatter of the next); then compound 4; then compound 1.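

In this assay, methyl in place of isopropyl, para to a methylsulfonyl group, gives a 2.8-fold higher number from compound 3 to compound 4 (0.45 log units; beyond the scatter). This position therefore responds to a change of group, and the shift lies beyond the usual scatter, although the step is modest. Nothing measured here bears on why the number moves.

On these data alone, whether an ethyl or a cyclopropyl group here would give a number closer to compound 3 or to compound 4 remains open. So does the size of this same change when a nitrile replaces the chloro group.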